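A Methyl Added to the Benzoyl Ring

This account rests on a few compounds, and the source may have more. Where it says the series, first, only, none or still open, it means among the compounds named here.

Compound 1 `O=C(CCN(Cc1ccc(C(=O)NO)cc1)C(=O)c1ccccc1)NCc1ccccc1` gives 3310 nM
Compound 2 `Cc1ccc(NC(=O)CCN(Cc2ccc(C(=O)NO)cc2)C(=O)c2ccccc2)cc1` gives 620 nM

In a functional assay on SK-N-AS cells (Homo sapiens) for antiproliferative activity, with a stated time of 72 h (a higher number here means a weaker inhibitor, a lower number a stronger inhibitor), compound 1 has the higher of the two numbers, so it is the weaker inhibitor of the pair. Compound 3 `Cc1ccc(C(=O)N(CCC(=O)NCc2ccccc2)Cc2ccc(C(=O)NO)cc2)cc1` differs from compound 1 by one change (methyl in place of hydrogen on an aromatic carbon) in which methyl replaces hydrogen on an aromatic carbon, turning benzoyl into (4-methylphenyl)carbonyl. Since a 5.3-fold lower number from compound 1 to compound 2 (0.73 log units; beyond the scatter) swaps benzyl for 4-methylphenyl on an amide-type nitrogen, a different place, it is only a loose guide. A small shift towards a lower number is expected (a 1.3-fold lower number from compound 1 to compound 3 (0.12 log units; within the scatter)) and it may stay within the scatter. Compound 3 is estimated at 2500 nM (expected range 1000 nM to 6000 nM).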

Compound 3, half-maximal inhibitory concentration: 910 nM
Beside the measured number, compound 3's estimate is 2.7-fold (0.44 log units) above it; measured number outside the range, below it.
By their numbers in this assay, from the lowest: compounds 2 and 3 (each within the scatter of the next); then compound 1.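

In this assay, one added methyl that turns benzoyl into (4-methylphenyl)carbonyl gives a 3.6-fold lower number from compound 1 to compound 3 (0.56 log units; beyond the scatter) and so moves the number beyond the scatter. This shows that the benzoyl ring, not only the group on the amide nitrogen, responds to change, even to a single added carbon. No measurement here accounts for this shift.

Going by these compounds, it remains open whether a chlorine, a methoxy group or an ethyl group at the same place would lower the number further. Also open, on these data alone, is whether this methyl would have a similar effect on compound 2.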